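Swapping methyl for iodine on a sulfonamide benzophenone

This account rests on a few compounds, and the source may have more. Where it says the series, first, only, none or still open, it means among the compounds named here.

Measured so far in an assay on CHO cells for binding affinity to integrin alpha-1 (Homo sapiens), read by WST assay, with a stated time of 2 h, tested at 50 uM; on this read-out higher numbers stand for more inhibition at the one concentration tested (going by the name of the read-out) and lower numbers for less inhibition:
Compound 1 `CN(c1ccc(C(=O)c2ccccc2)cc1)S(=O)(=O)c1ccc(Cl)cc1Cl` gives 0%.
Compound 2 `O=C(c1ccccc1)c1ccc(NS(=O)(=O)c2ccccc2)cc1` gives 0%.
Compound 3 `Cc1ccc(S(=O)(=O)Nc2ccc(C(=O)c3ccccc3)cc2)cc1` gives 35%.

Compound 3 stands highest of the three numbers; compounds 1 and 2 both sit far below it, beyond the scatter. Within the data shown here, the one step between measured compounds that differ in a single place runs a number 35 percentage points higher from compound 2 to compound 3 (beyond the scatter), showing that a small group at this position of the sulfonyl-bearing ring can shift the read-out by a large amount.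

Compound 4 `O=C(c1ccccc1)c1ccc(NS(=O)(=O)c2ccc(I)cc2)cc1` differs from compound 3 as follows: iodo in place of methyl on an aromatic carbon. Among the measured compounds shown here, no measured step replaces a methyl by iodo, so the direction of this change is not known from the data. The only related observation is the gain seen in a number 35 percentage points higher from compound 2 to compound 3 (beyond the scatter), which says that the substituted ring is better than the bare one. Iodo is also a substituent at that place, so compound 4 is expected to remain above compounds 1 and 2 but may fall short of compound 3. The estimated step is a number 10 percentage points lower from compound 3 to compound 4 (within the scatter), and compound 4 is expected to give 25% with a range from 0% to 55%.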

Compound 4, a percentage reported as inhibition, at one concentration (the size of the read-out at that concentration, not a potency): 85%
Compound 4: the middle estimate sits 60 percentage points below what was measured; measured number above the stated range.
By their numbers in this assay, from the lowest: compounds 1 and 2 (each within the scatter of the next); then compound 3; then compound 4.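

Iodo and methyl each add a single heavy atom at this place on the aromatic ring, yet they are far from interchangeable in this assay: iodo in place of methyl gives a number 50 percentage points higher from compound 3 to compound 4 (beyond the scatter) on the read-out. The earlier compounds shown here showed only that methyl beats hydrogen, with a number 35 percentage points higher from compound 2 to compound 3 (beyond the scatter) as the step, while iodo in place of hydrogen gives the larger a number 85 percentage points higher from compound 2 to compound 4 (beyond the scatter) and so shows that the identity of the group matters, not merely its presence. Nothing available here explains this difference between the two groups.

Still open, going by these compounds, is where other halogens at this place, such as chloro or bromo, would fall, and what an amine or a carboxylic acid there would do. On these data alone, with only one concentration tested, the potency of compound 4 also remains unknown.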